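The compounds below may be only part of what the source reports. "The series", "measured", "known", "first", "only" and "open" are said of these compounds alone.

Two compounds that share one core and differ only in the group on a saturated ring carbon have been measured in a physicochemical assay for lipophilicity, measured as octanol-water partition, at pH 7.4; a higher number here means a more lipophilic compound, a lower number a more polar compound. Compound 1 `O=C([C@H](O)CS(=O)(=O)c1ccc2cc(Cl)ccc2c1)N1CCC(N2Cc3cccn3C2=O)CC1` gives 2.6, and compound 2 `O=C([C@H](O)CS(=O)(=O)c1ccc2cc(Cl)ccc2c1)N1CCC(N2CCOC2=O)CC1` gives 1.75, the lower of the two numbers. Compound 3 `O=C([C@H](O)CS(=O)(=O)c1ccc2cc(Cl)ccc2c1)N1CCC(N2CCCS2(=O)=O)CC1` keeps the core and changes that group once more: a group of 7 heavy atoms (3 carbon, 1 nitrogen, 2 oxygen, 1 sulfur; one five-membered non-aromatic ring with 2 hetero atoms) in place of a group of 6 heavy atoms (3 carbon, 1 nitrogen, 2 oxygen; one five-membered non-aromatic ring with 2 hetero atoms), on a saturated ring carbon. The 2-oxo-1,3-oxazolidin-3-yl group leaves, and the group that enters also has one five-membered non-aromatic ring with 2 hetero atoms and no net charge. For the measured compounds named here, only one measured step bears on this change, at the same place: a number 0.85 log units lower from compound 1 to compound 2 (beyond the scatter). That step lost a five-membered aromatic ring with 1 hetero atom, and no such ring enters or leaves now. Going by the values given here, it is therefore only a weak guide, and no measured compound yet carries the entering group. From the compounds shown here alone, no step beyond the usual scatter is expected, and the direction stays open. The estimated change is a number 0.05 log units lower from compound 2 to compound 3 (within the scatter). Compound 3 is expected at 1.7, with an estimated range from 1.3 to 2.1.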

Compound 3, distribution coefficient: 1.69
For compound 3 the middle estimate is 0.01 log units above the measured one, and the stated range covers the measured number.
By their numbers in this assay, from the lowest: compounds 3 and 2 (each within the scatter of the next); then compound 1.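

In this assay, exchanging the 2-oxo-1,3-oxazolidin-3-yl group for the sulfur-bearing five-membered non-aromatic ring gives a number 0.06 log units lower from compound 2 to compound 3 (within the scatter), so at this saturated ring carbon the two groups cannot be told apart, even though the entering group has one more heavy atom and one more double bond outside aromatic rings. The group of compound 1, the only one of the three with a five-membered aromatic ring, stands apart from both others: the new comparison gives a number 0.91 log units lower from compound 1 to compound 3 (beyond the scatter), and this matches the earlier a number 0.85 log units lower from compound 1 to compound 2 (beyond the scatter) in lying beyond the scatter. Nothing measured here explains why the two non-aromatic groups read alike.

The compounds shown cannot separate the aromatic ring of compound 1 from its larger overall size, since its group differs from the other two in both at once. Also open, from the compounds shown here alone, is how a group carrying an amine or a carboxylic acid on this saturated ring carbon would read in this assay.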